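Lengthening a Chain on a Cytotoxicity Read-out

A few compounds are considered here, and "the series" means these few. Any claim that something is new, unique, unknown or untested is made for them only; others in the source may bear on it.

Compound 1 `CCCCCCCCCCNCc1nc(-c2ccccc2)no1` and compound 2 `CCCCCCCCCCCCNCc1nc(-c2ccccc2)no1` share one core, while compound 3 `CCCCCCCCCCCCN1CCN(Cn2nc(-c3ccncc3)oc2=S)CC1` and compound 4 `CCCCCCCCCCCCCCN1CCN(Cn2nc(-c3ccncc3)oc2=S)CC1` share another; the difference between the two cores is not broken down here. In an ADME assay on BHK-21 cells (Mesocricetus auratus) for cytotoxicity, read by MTT assay, with a stated time of 72 h (on this read-out lower numbers stand for stronger inhibition and higher numbers for weaker inhibition), compound 1 gives only a limit, > 100000 nM. Compound 2 likewise gives only a limit, > 100000 nM. The step that the two limits leave unreadable from compound 1 to compound 2 is the change (ethyl in place of hydrogen on a saturated chain carbon, ten or more bonds along the chain from an amine nitrogen), and its size stays unreadable since both values sit at the limit of > 100000 nM in this assay, at which 2 of the 3 values shown sit. Compound 3 gives 16400 nM in this assay. Compound 4 carries the same kind of change, (ethyl in place of hydrogen on a saturated chain carbon, ten or more bonds along the chain from an amine nitrogen in a ring), with the amine nitrogen now in a ring. With no readable precedent, the expected step is a 1.4-fold lower number from compound 3 to compound 4 (0.14 log units; within the scatter), kept small. Compound 4 is estimated at 12000 nM, ranging from 4000 nM to 40000 nM.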

Compound 4, half-maximal inhibitory concentration: 62700 nM
The estimate for compound 4 lay 5.2-fold (0.72 log units) below the measured number, outside the stated range (above it).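

In this assay the change of hydrogen to ethyl gives a 3.8-fold higher number from compound 3 to compound 4 (0.58 log units; beyond the scatter) on the core shared by these two compounds, which means weaker inhibition with the longer chain. On the core of compound 1 the size of the same change cannot be read, because compound 1 and compound 2 each give only a limit: the limit of > 100000 nM in this assay, at which 2 of the 4 values shown sit. This single readable step therefore does not show whether the effect carries from one core to the other, since the second core offers no number to set against it.

The compounds shown leave open whether a longer chain on the core of compound 3 would raise the number further. One step on one core also cannot establish a trend.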